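The source may hold more compounds than are shown below. What is called first, only, known or untested is meant among the compounds shown, and "the series" means these compounds.

Measured compounds:
compound 1, `COc1ncc(-c2ccc3c(c2)NC(=O)CO3)cc1NS(=O)(=O)c1ccc(F)cc1`: 32300 nM
compound 2, `COc1ncc(-c2ccc3c(c2)N(c2ccc(F)cc2)C(=O)CO3)cc1NS(=O)(=O)c1ccc(F)cc1`: > 40000 nM
compound 3, `O=C1COc2ccc(-c3cnc(Cl)c(NS(=O)(=O)c4ccc(F)cc4)c3)cc2N1c1ccc(F)cc1`: 32600 nM

The three measured compounds share a sulfonamide-bearing pyridine joined to a fused bicyclic lactam, and they were tested in a functional assay on MCF7 cells (Homo sapiens) for antiproliferative activity, read by MTT assay, with a stated time of 72 h; on this read-out lower numbers stand for stronger inhibition and higher numbers for weaker inhibition. In this assay compound 1 gives 32300 nM. Compound 2 reaches only a limit of the assay, > 40000 nM; this is the limit of > 40000 nM in this assay, at which 1 of the 3 values shown sits. Compound 3 gives 32600 nM in this assay, and its value and that of compound 1 lie within the scatter of each other.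

Two single changes connect the measured set. The change hydrogen in place of 4-fluorophenyl on an amide-type nitrogen in a ring produces an at least 1.2-fold lower number from compound 2 to compound 1 (0.09 log units; that floor lies within the scatter). The change of core, (chloro in place of methoxy on an aromatic carbon), produces an at least 1.2-fold lower number from compound 2 to compound 3 (0.08 log units; that floor lies within the scatter). Both steps start from a limit, so only a floor for each is known.

Compound 4, `O=C1COc2ccc(-c3cnc(Cl)c(NS(=O)(=O)c4ccc(F)cc4)c3)cc2N1`, is not yet measured. It differs from compound 3 by hydrogen in place of 4-fluorophenyl on an amide-type nitrogen in a ring, which is the same change as that made from compound 2 to compound 1; it is made at two points in this set. The core of compound 4 differs from that of compound 1 by chloro in place of methoxy on an aromatic carbon. Since the earlier instance of this change gave at least the floor seen in an at least 1.2-fold lower number from compound 2 to compound 1 (0.09 log units; that floor lies within the scatter), and compound 1 and compound 3 sit within the scatter of each other, compound 4 is expected to shift by about a 1.3-fold lower number from compound 3 to compound 4 (0.10 log units; within the scatter). Compound 4 is therefore estimated at 26000 nM, with a range of 10000 nM to 60000 nM.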

Compound 4, half-maximal inhibitory concentration: > 40000 nM
Compound 4 ended at the assay's limit; the forecaster's own chance of this, stated with the estimate: 20%; middle value at least 1.5-fold (0.18 log units) from the limit.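

In this assay compound 4 gives > 40000 nM, which is a limit of the assay and not a number: the limit of > 40000 nM in this assay, at which 2 of the 4 values shown sit.

Hydrogen in place of 4-fluorophenyl on the amide-type nitrogen in a ring gives an at least 1.2-fold higher number from compound 3 to compound 4 (0.08 log units; that floor lies within the scatter), and the two instances of this change have floors printed in opposite directions, yet this shows neither that the change carries over from one core to the other nor that it reverses: the same change on two cores in this assay, an at least 1.2-fold lower number (0.09 log units; that floor lies within the scatter) from compound 2 to compound 1 and an at least 1.2-fold higher number (0.08 log units; that floor lies within the scatter) from compound 3 to compound 4; the limit leaves it open whether they differ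

Chloro in place of methoxy on the aromatic carbon gives an at least 1.2-fold higher number from compound 1 to compound 4 (0.09 log units; that floor lies within the scatter), and this pair likewise offers no measured size that could be carried from one core to the other: the same change on two cores in this assay, an at least 1.2-fold lower number (0.08 log units; that floor lies within the scatter) from compound 2 to compound 3 and an at least 1.2-fold higher number (0.09 log units; that floor lies within the scatter) from compound 1 to compound 4; the limit leaves it open whether they differ

The compounds shown leave open how the series would respond to other groups on the amide-type nitrogen in a ring, such as a methyl or a short chain ending in an amine, or to a nitrile in place of the chloro or methoxy on the aromatic carbon. They also leave open how large either change would be on a core where neither compound of the pair sits at the limit.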